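Methoxy Added to Compound 3: What the Numbers Suggest

This account rests on a few compounds, and the source may have more. Where it says the series, first, only, none or still open, it means among the compounds named here.

In a functional assay on HCT-8 cells (Homo sapiens) for cytotoxicity, read by MTT assay, with a stated time of 48 h (a lower number here means a stronger inhibitor, a higher number a weaker inhibitor), compound 3 `CN1CCC(NC(=O)c2ccc(Nc3ncc(F)c(NC4CCCC4)n3)cc2)CC1` gives 16000 nM, the largest of the three numbers, although compound 1 `COc1cc(C(=O)NC2CCN(C)CC2)ccc1Nc1ncc(Br)c(NC2CCCC2)n1`, which gives 12000 nM, lies within the scatter of it; compound 2 `COc1cc(C(=O)NC2CCN(C)CC2)ccc1Nc1ncc(Cl)c(NC2CCCC2)n1` gives 4400 nM, beyond that scatter. Within the data shown here, the only measured step, a 2.7-fold lower number from compound 1 to compound 2 (0.44 log units; beyond the scatter), concerns the halogen and does not bear on the change considered here. Compound 4 `COc1cc(C(=O)NC2CCN(C)CC2)ccc1Nc1ncc(F)c(NC2CCCC2)n1` differs from compound 3 by methoxy in place of hydrogen on an aromatic carbon. Among the measured compounds shown here, no measured pair shows this change on its own, and compounds 1 and 2, which both carry the methoxy, fall on either side of the scatter around compound 3. Compound 4 is therefore expected to differ from compound 3 by a 1.6-fold lower number from compound 3 to compound 4 (0.20 log units; within the scatter), no more than the scatter. The estimate for compound 4 is 10000 nM, between 3500 nM and 28000 nM.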

Compound 4, half-maximal inhibitory concentration: 2100 nM
For compound 4 the middle estimate is 4.8-fold (0.68 log units) above the measured one, and the stated range ends above it.
By their numbers in this assay, from the lowest: compound 4; then compound 2; then compounds 1 and 3 (each within the scatter of the next).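

In this assay, among these compounds, methoxy in place of hydrogen on an aromatic carbon ortho to a large group gives a 7.6-fold lower number from compound 3 to compound 4 (0.88 log units; beyond the scatter) in the only pair that shows this change on its own, so this position responds to the change. With the methoxy in place, fluoro in place of chloro gives a 2.1-fold lower number from compound 2 to compound 4 (0.32 log units; beyond the scatter) and fluoro in place of bromo gives a 5.7-fold lower number from compound 1 to compound 4 (0.76 log units; beyond the scatter) on the shared core. Compound 4 therefore has the lowest number of the four compounds.

On these data alone, whether an ethoxy or a hydroxyl group at this position would act like methoxy remains open, as does whether methoxy has the same effect with chloro or bromo on the core. Nothing measured here gives a cause for these steps.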